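This account rests on a few compounds, and the source may have more. Where it says the series, first, only, none or still open, it means among the compounds named here.

Working notes on the series, read in a toxicity assay on L02 cells (Homo sapiens) for cytotoxicity, read by MTT assay, with a stated time of 72 h; a lower number here means a stronger inhibitor, a higher number a weaker inhibitor. Going by the values given here, compound 1 (`CN(C)CCCCCn1c2c(c3ccccc31)C(=O)c1c[n+]([O-])c3ccccc3c1C2=O`) gives 240 nM, the lower of the two numbers measured so far. Compound 2 (`O=C1c2c[n+]([O-])c3ccccc3c2C(=O)c2c1c1ccccc1n2Cc1cn([C@H]2O[C@H](CO)[C@@H](O)[C@H]2O)nn1`) gives 950 nM, and this gap between the two compounds lies beyond the scatter. Compound 3 (`O=C1c2c[n+]([O-])c3ccccc3c2C(=O)c2c1c1ccccc1n2CCCCn1ccnc1`) has not yet been measured. Its structure differs from that of compound 1 as follows: 1H-imidazol-1-yl in place of (dimethylamino)methyl on a saturated chain carbon, four bonds along the chain from an aromatic nitrogen. In words, 1H-imidazol-1-yl stands in place of (dimethylamino)methyl on a saturated chain carbon, four bonds along the chain from an aromatic nitrogen.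

Among the compounds with values here, no measured pair isolates this change, so the expectation rests on thin evidence. Within the data shown here, the only pointer is compound 2, which also lacks the (dimethylamino)methyl group and gives 950 nM, although it differs from compound 1 in more than that group. A moderate move toward a higher number, meaning a weaker inhibitor, is therefore expected in this assay, and the expected step is a 2.3-fold higher number from compound 1 to compound 3 (0.36 log units; beyond the scatter). A result within the scatter of compound 1 remains possible. For compound 3 the estimated value is 550 nM, with an expected range of 200 nM to 1500 nM.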

Compound 3, half-maximal inhibitory concentration: 150 nM
The estimate for compound 3 lay 3.7-fold (0.56 log units) above the measured number, and the stated range ends above it.
By their numbers in this assay, from the lowest: compounds 3 and 1 (each within the scatter of the next); then compound 2.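

In this assay, going by these compounds alone, 1H-imidazol-1-yl in place of (dimethylamino)methyl on a saturated chain carbon, four bonds along the chain from an aromatic nitrogen, gives a 1.6-fold lower number from compound 1 to compound 3 (0.20 log units; within the scatter) as the first step that isolates a single change. At this position, the two groups therefore cannot be told apart in this read-out, and a five-membered aromatic ring with 2 hetero atoms can stand at the end of the chain without a shift beyond the scatter. No supporting measurement bears on why the two groups read alike here.

The compounds shown leave open whether other groups at this position, such as a morpholine, a piperidine or a carboxylic acid, would also stay within the scatter of compound 1, or whether any of them would move the number clearly. They also leave open how a shorter or longer chain would read with 1H-imidazol-1-yl at its end, since a single step at one position says nothing about the chain as a whole.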